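The source may hold more compounds than are shown below. What is called first, only, known or untested is meant among the compounds shown, and "the series" means these compounds.

Working notes on the series.

Going by the values given here, compound 1 `COc1ccc(/C=C/C(=O)OC[C@H]2O[C@@H](O[C@@H]3OC=C[C@@]4(O)[C@H](O)C[C@](C)(O)[C@@H]34)[C@H](O)[C@@H](O)[C@@H]2O)cc1` is one of two compounds measured so far in a functional assay (Cortical neurone cells, Rattus norvegicus, strain Sprague-Dawley), read by spectrophotometry and LDH release, with stated times of 1 h and 24 h, tested at 0.1 uM; a higher number here means a stronger effect of the compound at the concentration tested, a lower number a weaker effect. In this assay compound 1 gives 39.1%, and compound 2 `COc1ccc(/C=C\C(=O)O[C@@]2(C)C[C@@H](O)[C@]3(O)C=CO[C@@H](O[C@@H]4O[C@H](CO)[C@@H](O)[C@H](O)[C@H]4O)[C@@H]32)cc1` gives 40.7% in the same measurement; the two values lie within the usual scatter of each other, so no ranking between compound 1 and compound 2 can be drawn from them.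

The next compound, compound 3 `COc1ccc(/C=C\C(=O)OC[C@H]2O[C@@H](O[C@@H]3OC=C[C@@]4(O)[C@H](O)C[C@](C)(O)[C@@H]34)[C@H](O)[C@@H](O)[C@@H]2O)cc1`, is not yet measured. How compound 3 differs from compound 1: the two compounds have the same atoms and bonds and differ only in configuration as drawn: 1 of 11 stereo elements differ; a double bond is drawn E in compound 1 and Z in compound 3. Among the compounds with values here, no step between two measured compounds is known, so the expectation rests only on the two values shown. Compound 2, which carries the Z-drawn double bond, gives a value in this assay that is within the scatter of the value of compound 1, so no step beyond the scatter is expected for compound 3.

The step from compound 1 to compound 3 is therefore expected at a number 0.9 percentage points higher from compound 1 to compound 3 (within the scatter). For compound 3 a value of 40% is estimated in this assay, within a range of 30% to 50%.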

Compound 3, a percentage reported as activity, at one concentration (the size of the read-out at that concentration, not a potency): 33.3%
For compound 3 the middle estimate is 6.7 percentage points above the measured one; the measured number falls inside the stated range.
By their numbers in this assay, from the lowest: compounds 3, 1 and 2 (each within the scatter of the next).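

Going by these compounds alone, this pair gives the first measured step, and that step isolates a single stereo element: the fact that compounds 1 and 3 differ only in the configuration as drawn. Redrawing the double bond from E to Z gives a number 5.8 percentage points lower from compound 1 to compound 3 (within the scatter) in this assay, so at this position the change of configuration is not resolved from the scatter of this measurement. Each read-out is also the size of the effect at one concentration, so the step says nothing about potency.

Going by these compounds, whether the two double bond forms would separate at other concentrations remains open. Also open, on these data alone, is whether a group of a different kind, such as an amine in place of the methoxy group or a carboxylic acid in place of the whole cinnamoyl-type ester, would give a step beyond the scatter.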